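The source may report more compounds than this note shows. Statements on the series, on what has been measured and on what is new or still open speak of the compounds shown alone.

Measured compounds:
- compound 1 `COc1cc2c(cc1OC)C(CC(=O)Nc1ccccc1)CC2`: 31.3%
- compound 2 `COc1cc2c(cc1OC)C(CC(=O)Nc1ccc(C)cc1)CC2`: 34.4%
- compound 3 `COc1ccccc1NC(=O)CC1CCc2cc(OC)c(OC)cc21`: 28.1%

All three share a core and an amide bearing an aryl group on its nitrogen. In a functional assay on the whole organism (strain Wistar) for inhibition, with Rattus norvegicus as the target, read by paw edema, with a stated time of 1 h, at a dose of 100 mg/kg (on this read-out lower numbers stand for less inhibition and higher numbers for more inhibition at the one dose given (going by the name of the read-out)), compound 3 gives the smallest of the three numbers, yet the gaps that separate it from the others, a number 3.2 percentage points lower from compound 1 to compound 3 (within the scatter) and a number 6.3 percentage points lower from compound 2 to compound 3 (within the scatter), are both within the scatter, so the three compounds cannot be told apart on these data.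

Compound 4 `COc1cc2c(cc1OC)C(CC(=O)Nc1cccnc1)CC2` is not yet measured. It differs from compound 3 in one place: pyridin-3-yl in place of 2-methoxyphenyl on an amide-type nitrogen. For the measured compounds named here, the only measured step that changes the whole aryl group on the amide nitrogen is a number 6.3 percentage points lower from compound 2 to compound 3 (within the scatter); the steps of a number 3.1 percentage points higher from compound 1 to compound 2 (within the scatter) and a number 3.2 percentage points lower from compound 1 to compound 3 (within the scatter) change one substituent on that ring. None of these steps left the scatter. The change to compound 4 is of the same kind, so in this assay no step beyond the scatter is expected, in either direction. For compound 4 the estimate is therefore 31%, with a range of 20% to 42%, which means an expected step of a number 2.9 percentage points higher from compound 3 to compound 4 (within the scatter).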

Compound 4, a percentage reported as inhibition, in the whole organism at one dose (the size of the read-out at that dose, not a potency): 25%
Compound 4: middle estimate off by 6 percentage points, on the high side; the measured number falls inside the stated range.
By their numbers in this assay, from the lowest: compounds 4, 3, 1 and 2 (each within the scatter of the next).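

In this assay the steps of a number 3.1 percentage points lower from compound 3 to compound 4 (within the scatter) and a number 9.4 percentage points lower from compound 2 to compound 4 (within the scatter) and a number 6.3 percentage points lower from compound 1 to compound 4 (within the scatter) all stay within the scatter, so compound 4 cannot be told apart from the other three. The earlier compounds shown here carried only aryl groups with a carbon-only aromatic ring on the amide-type nitrogen, whereas pyridin-3-yl shows that a ring with a hetero atom at this position also gives no step beyond the scatter. No measurement is available that bears on why these numbers come out as they do.

Going by these compounds, it remains open whether a carboxylic acid or an aminoalkyl chain on this aromatic ring, or a longer chain in place of the ring on the amide-type nitrogen, would leave the scatter. The compounds shown also leave open whether they separate at another dose or time.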